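Swapping a bicyclic ring for pyrimidine on the pyrrolidine nitrogen

The compounds below may be only part of what the source reports. "The series", "measured", "known", "first", "only" and "open" are said of these compounds alone.

The measured compounds, each with its result in a physicochemical assay for solubility, measured as kinetic solubility; a higher number here means a more soluble compound, a lower number a less soluble compound:

Compound 1, `Nc1nccc(N2CC[C@H](NC(=O)Nc3ccc(Cl)c(C(F)(F)F)c3)C2)n1`, gives 30300 nM.
Compound 2, `O=C(Nc1ccc(Cl)c(C(F)(F)F)c1)N[C@H]1CCN(c2ccc3nncn3n2)C1`, gives 1000 nM.
Compound 3, `CCN1CCN(Cc2ccc(NC(=O)N[C@H]3CCN(c4ccnc(NC)n4)C3)cc2C(F)(F)F)CC1`, gives 132000 nM.

Compound 2 stands lowest of the three in this assay; compound 1 is nearest, and compound 3 furthest, with both differences beyond the scatter. The new compound 4, `O=C(Nc1ccc(Cl)c(C(F)(F)F)c1)N[C@H]1CCN(c2ccncn2)C1`, differs from compound 2 in one place: a group of 6 heavy atoms (4 carbon, 2 nitrogen; one six-membered aromatic ring with 2 hetero atoms) in place of a group of 9 heavy atoms (5 carbon, 4 nitrogen; one five-membered aromatic ring with 3 hetero atoms, one six-membered aromatic ring with 2 hetero atoms), on an amine nitrogen in a ring.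

Among the compounds with values here, one measured step bears on this. Compound 1 and compound 2 differ at the same amine nitrogen, where the group of 9 heavy atoms with two aromatic rings replaced a group of 7 heavy atoms with one six-membered ring, and that gave a 30-fold lower number from compound 1 to compound 2 (1.48 log units; beyond the scatter). Compound 4 goes the other way, back to a single six-membered ring, though without the extra nitrogen that compound 1 carries. A rise beyond the scatter is therefore expected, somewhat smaller than the step from compound 1 to compound 2. For compound 4 the estimate is 10000 nM, with a range from 3000 nM to 30000 nM, meaning an expected step of a 10-fold higher number from compound 2 to compound 4 (1.00 log units; beyond the scatter).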

Compound 4, solubility: 2400 nM
For compound 4 the middle estimate is 4.2-fold (0.62 log units) above the measured one; the whole stated range lies above it.
By their numbers in this assay, from the lowest: compound 2; then compound 4; then compound 1; then compound 3.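

In this assay, the single-ring pyrimidin-4-yl group on the ring amine nitrogen gives only a 2.4-fold higher number from compound 2 to compound 4 (0.38 log units; beyond the scatter), so leaving the two-ring group behind is not enough to reach the level of compound 1. Compound 4 also separates the earlier 30-fold lower number from compound 1 to compound 2 (1.48 log units; beyond the scatter) into two parts: the modest step above and a larger one, a 13-fold lower number from compound 1 to compound 4 (1.10 log units; beyond the scatter), which comes with hydrogen in place of amino on an aromatic carbon. At this position, then, that one amino group goes with more of the change in the number than the choice between the two ring groups does. Nothing available here explains why these steps differ in size. On these data alone, whether a hydroxyl or methoxy group in place of that amino group would give a number nearer compound 1 or compound 4 remains open.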